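This account rests on a few compounds, and the source may have more. Where it says the series, first, only, none or still open, it means among the compounds named here.

Going by the values given here, compound 2 `COc1ccc(N2C[C@@H](C)N[C@@H](C)C2)cc1NS(=O)(=O)c1ccc(-c2ccc(C)o2)cc1` holds the lower of the two numbers so far in a functional assay for agonist activity at growth hormone secretagogue receptor type 1 (Homo sapiens), read by FLIPR; a higher number here means that more compound is needed for the effect, a lower number that less compound is needed: compound 2 gives 0.794 nM, whereas compound 1 `COc1cccc(-c2ccc(S(=O)(=O)Nc3cc(N4C[C@@H](C)N[C@@H](C)C4)ccc3OC)cc2)c1` gives 2 nM, the two being separated by the single measured step, a 2.5-fold lower number from compound 1 to compound 2 (0.40 log units; beyond the scatter). Compound 3 `COc1ccc(N2C[C@@H](C)N[C@@H](C)C2)cc1NS(=O)(=O)c1ccc(OCc2ccccc2)cc1` has not yet been measured in this assay. It differs from compound 2 in one place: benzyloxy in place of 5-methylfuran-2-yl on an aromatic carbon. Among the compounds with values here, the only measured step exchanged one aromatic ring for another of a different size at the same carbon, and it shifted the number by a modest amount. Within the data shown here, the change to compound 3 is of another kind, since the entering benzyloxy carries its ring on an oxygen and a single carbon rather than joining directly, and no measured pair speaks to that. Among the measured compounds shown here, with nothing closer to lean on, the expectation is a modest step in this assay towards a higher number, of a size comparable to the one step seen, though a step within the scatter cannot be ruled out. Compound 3 is therefore estimated at 2.5 nM, with a range from 0.6 nM to 10 nM, corresponding to an expected step of a 3.1-fold higher number from compound 2 to compound 3 (0.50 log units; beyond the scatter).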

Compound 3, half-maximal effective concentration: 100 nM
The estimate for compound 3 lay 40-fold (1.60 log units) below the measured number; the whole stated range lies below it.
By their numbers in this assay, from the lowest: compound 2; then compound 1; then compound 3.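

In this assay, going by these compounds alone, the aromatic carbon para to a large group proves far less forgiving than the one earlier exchange suggested: against the modest 2.5-fold lower number from compound 1 to compound 2 (0.40 log units; beyond the scatter), benzyloxy in place of 5-methylfuran-2-yl gives a 130-fold higher number from compound 2 to compound 3 (2.10 log units; beyond the scatter), and benzyloxy in place of 3-methoxyphenyl gives a 50-fold higher number from compound 1 to compound 3 (1.70 log units; beyond the scatter). Across these three compounds, the two groups whose ring joins the core directly differ far less from each other than either does from benzyloxy, whose ring is held through an oxygen and a single carbon, while 5-methylfuran-2-yl and benzyloxy have the same counts of hydrogen-bond donors and acceptors and no net charge, so those counts do not separate them. Nothing available explains why the number rises so sharply.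

The compounds shown leave open which part of benzyloxy goes with the rise: the oxygen, the added carbon or the unsubstituted ring. A simple methoxy group, a phenyl ring joined directly or a benzylamino group at the same carbon would help to pull these parts apart.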